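Swapping a Methoxy for Cyclopropyl on an Acid Agonist

The source may report more compounds than this note shows. Statements on the series, on what has been measured and on what is new or still open speak of the compounds shown alone.

Compound 1, `COC(CC(=O)O)c1ccc(OCc2cccc(-c3c(C)cccc3C)c2)s1`, is an acid-bearing molecule built on a shared core. In a functional assay on cells for agonist activity at Free fatty acid receptor 1 (Homo sapiens), read by calcium flux (a lower number here means that less compound is needed, a higher number that more compound is needed for the effect), compound 1 gives 210 nM, the lowest of the three numbers gathered so far. Compound 3, `Cc1cccc(C)c1-c1cccc(COc2csc(CCC(=O)O)c2)c1`, gives 2320 nM in this assay, and compound 2, `Cc1cccc(C)c1-c1cccc(OCc2cn(CCC(=O)O)nn2)c1`, gives 14700 nM; both of these gaps lie beyond the usual scatter, so compound 1 is the most potent of the three. No two of these compounds differ in only one place, so none of the gaps can be tied to a single structural change.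

Compound 4, `Cc1cccc(C)c1-c1cccc(COc2ccc(C(CC(=O)O)C3CC3)s2)c1`, has not yet been measured. Its difference from compound 1 is: cyclopropyl in place of methoxy on a saturated chain carbon bound to an aromatic carbon and a saturated chain carbon. For the measured compounds named here, no measured pair isolates this swap, so its effect can only be estimated from the fact that compound 1 already sits at the low end of the numbers seen. The step of a 1.6-fold lower number from compound 1 to compound 4 (0.21 log units; within the scatter) is expected to be small, either a slightly lower number or no change beyond the scatter. Compound 4 is estimated to give 130 nM in this assay, with a likely range from 40 nM to 450 nM.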

Compound 4, half-maximal effective concentration: 3920 nM
Compound 4: the middle estimate sits 30-fold (1.48 log units) below what was measured; the whole stated range lies below it.
By their numbers in this assay, from the lowest: compound 1; then compounds 3 and 4 (each within the scatter of the next); then compound 2.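

For the compounds shown here, this is the first pair in the set that differs in only one place, so a gap in this assay can now be tied to a single structural change: cyclopropyl in place of methoxy gives a 19-fold higher number from compound 1 to compound 4 (1.27 log units; beyond the scatter). The result shows that this saturated chain carbon, bound to an aromatic carbon and a saturated chain carbon, is sensitive to what it carries, since a swap of just a few heavy atoms moves the number by a large step. The swap replaces 2 heavy atoms, including 1 hydrogen-bond acceptor, with 3 carbon atoms in a three-membered ring and no acceptor, but no measurement here explains why the number rises.

This single pair cannot separate the effect of losing the oxygen from that of adding the ring or the extra heavy atom, as all three changes arrive together. An ethyl group, which has no ring and no oxygen, and a hydroxyl group, which keeps an oxygen on this carbon, would be the kind of neighbours needed to pull those changes apart.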